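The compounds below may be only part of what the source reports. "The series", "measured", "known", "first", "only" and "open" are said of these compounds alone.

In a functional assay on SNB-75 cells (Homo sapiens) for inhibition, read by sulforhodamine B assay, with a stated time of 48 h (on this read-out lower numbers stand for stronger inhibition of growth and higher numbers for weaker inhibition of growth), compound 2 (`COc1ccc(C2([C@H]3C[C@H](n4cc(C)c(=O)[nH]c4=O)O[C@@H]3CO[Si](C)(C)C(C)(C)C)SCCCS2)cc1OC`) gives 10000 nM. Among the measured compounds shown here, this is the only number available, so it cannot be placed as high or low against any other compound. Compound 1 (`Cc1cn([C@H]2C[C@H](CC3=CC(=O)C(=O)C=C3)[C@@H](CO[Si](C)(C)C(C)(C)C)O2)c(=O)[nH]c1=O`) was entered in this assay, and its entry reads no result reported.

Compound 3 (`COc1ccc(C2([C@H]3C[C@@H](n4cc(C)c(=O)[nH]c4=O)O[C@@H]3CO[Si](C)(C)C(C)(C)C)SCCCS2)cc1OC`) is the stereochemical counterpart of compound 2: the two compounds have the same atoms and bonds and differ only in configuration as drawn: 1 of 3 stereo elements differ; a stereocentre at a saturated ring carbon is drawn R in compound 2 and S in compound 3. The two compounds have the same atoms and bonds, and a stereocentre at a saturated ring carbon is drawn R in compound 2 and S in compound 3.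

For the measured compounds named here, no step between measured compounds exists to show what such a change does in this assay, so the data offer no direction for it. The expectation therefore rests on compound 2 alone, at 10000 nM, and no change beyond the usual scatter is expected. The estimated step of no change at the digits printed from compound 2 to compound 3 (within the scatter) is correspondingly small, and it carries wide uncertainty. For compound 3 the expected value is 10000 nM, with an estimated range of 4000 nM to 25000 nM.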

Compound 3, concentration for 50% growth inhibition: 17000 nM
The estimate for compound 3 lay 1.7-fold (0.23 log units) below the measured number, and the stated range covers the measured number.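

In this assay, inverting the stereocentre at the saturated ring carbon from R to S gives a 1.7-fold higher number from compound 2 to compound 3 (0.23 log units; within the scatter), so this single change does not separate the two compounds on this read-out. Among the compounds shown here, until this pair, the account held no step at all: compound 2 stood alone with its number, compound 1 had no result reported, and nothing indicated whether the configuration at this position mattered for inhibition of growth in these cells. The pair now gives a direct reading of that one stereocentre, with nothing else in the structure to confound it: the fact that compounds 2 and 3 differ only in the configuration as drawn

The compounds shown leave open whether the other two stereo elements would behave in the same way, and whether this inversion would remain as small a step on a compound with a lower number in this assay. They also leave open how the read-out would respond to a different group on the shared core, such as an amine or a carboxylic acid, and whether the configuration at this carbon would matter in its presence.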